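The compounds below may be only part of what the source reports. "The series", "measured", "known", "first", "only" and "open" are said of these compounds alone.

Measured so far in a functional assay on U-87MG ATCC cells for antiproliferative activity against U-87 MG (Homo sapiens), read by MTT assay, with a stated time of 48 h; on this read-out lower numbers stand for stronger inhibition and higher numbers for weaker inhibition:

compound 1 `C/C(=C\CC/C(C)=C/CC[C@@H]1[C@@]2(C)CCC(=O)C(C)(C)[C@H]2CC[C@@]1(C)O)CC/C=C(\C)C(=O)OCc1cn(-c2cccc(O)c2)nn1` gives > 150000 nM
compound 2 `C/C(=C\CC/C(C)=C/CC[C@@H]1[C@@]2(C)CCC(=O)C(C)(C)[C@H]2CC[C@@]1(C)O)CC/C=C(\C)C(=O)OCc1cn(-c2ccc(F)cc2)nn1` gives > 150000 nM

Compound 1 returns only a limit of the assay, > 150000 nM, not a number. Compound 2 likewise returns only a limit, > 150000 nM. Among the measured compounds shown here, the single measured step, a step that the two limits leave unreadable from compound 1 to compound 2, is thus unreadable in size and direction; both values sit at the limit of > 150000 nM in this assay, at which 2 of the 2 values shown sit.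

Compound 3 `C/C(=C\CC/C(C)=C/CC[C@@H]1[C@@]2(C)CCC(=O)C(C)(C)[C@H]2CC[C@@]1(C)O)CC/C=C(\C)C(=O)OCc1cn(-c2ccc(C(C)(C)C)cc2)nn1` is not yet measured. It differs from compound 1 by 4-(tert-butyl)phenyl in place of 3-hydroxyphenyl on an aromatic nitrogen. For the measured compounds named here, the one step that bears on this change, a step that the two limits leave unreadable from compound 1 to compound 2, is itself an exchange of the group on the aromatic nitrogen and shows no readable size, so no step beyond the scatter can be expected in this assay in either direction, and a further limit is the likeliest outcome. Compound 3 is expected at 150000 nM, between 50000 nM and 500000 nM. The estimated step is a number no higher from compound 1 to compound 3 (the limit leaves the size open).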

Compound 3, half-maximal inhibitory concentration: > 150000 nM
Compound 3: no number, only a limit; the forecaster's own chance of this, stated with the estimate: 75%; the middle value sits exactly at the limit.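

Among the compounds shown here, compound 3 gives > 150000 nM in this assay as a limit, not a number, so no step from compound 1 or compound 2 to compound 3 can be read. The compounds shown leave open whether any group on the aromatic nitrogen changes this read-out at all.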